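Carbonyl substituent variation in a positive allosteric modulator series

The source may report more compounds than this note shows. Statements on the series, on what has been measured and on what is new or still open speak of the compounds shown alone.

Measured compounds:
compound 1 `CC(=O)N1CCc2nc(C#Cc3ccccc3)sc2C1` — > 10000 nM
compound 2 `O=C(c1cccc(Cl)c1)N1CCc2nc(C#Cc3ccccc3)sc2C1` — 8.7 nM
compound 3 `O=C(N1CCCCC1)N1CCc2nc(C#Cc3ccccc3)sc2C1` — 75 nM
compound 4 `O=C(N1CCC(F)CC1)N1CCc2nc(C#Cc3ccccc3)sc2C1` — not yet measured

In an assay on HEK293 cells for positive allosteric modulation of metabotropic glutamate receptor 5 (Homo sapiens), read by FLIPR, with a stated time of 1 h (on this read-out lower numbers stand for an effect already at smaller amounts and higher numbers for an effect only at larger amounts of compound), compound 1 gives > 10000 nM, which is a limit of the assay and not a number. Compound 1 therefore stands at the limit of > 10000 nM in this assay, at which 1 of the 3 values shown sits, the weakest end of the series as far as the numbers reach. Replacing the methyl on the carbonyl carbon gives the two measured steps: an at least 1100-fold lower number from compound 1 to compound 2 (3.06 log units; beyond the scatter) and an at least 130-fold lower number from compound 1 to compound 3 (2.12 log units; beyond the scatter). Between the two larger groups, an 8.6-fold higher number from compound 2 to compound 3 (0.94 log units; beyond the scatter).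

Compound 4 differs from compound 1 as follows: 4-fluoropiperidin-1-yl in place of methyl on a carbonyl carbon. The step from compound 1 to compound 3 bears most directly on this change, as 4-fluoropiperidin-1-yl differs from piperidin-1-yl only by the fluorine; the step to compound 2 shows the same direction. A large step in the same direction is therefore expected, roughly of the size seen for compound 3, with the fluorine not expected to move the number beyond the scatter in either direction.

The expected step is an at least 160-fold lower number from compound 1 to compound 4 (2.22 log units; beyond the scatter). Compound 4 is estimated at 60 nM, with a range of 20 nM to 200 nM.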

Compound 4, half-maximal effective concentration: 74 nM
The estimate for compound 4 lay 1.2-fold (0.09 log units) below the measured number; the measured number falls inside the stated range.
By their numbers in this assay, from the lowest: compound 2; then compounds 4 and 3 (each within the scatter of the next). At a limit, above all of these: compound 1.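

In this assay, for the compounds shown here, fluoro in place of hydrogen on a saturated ring carbon gives a 1.0-fold lower number from compound 3 to compound 4 (0.01 log units; within the scatter), so compound 3 and compound 4 cannot be told apart, and this ring carbon accepts the fluorine without a readable cost, which the earlier compounds could not show. On the carbonyl carbon, the 4-fluoropiperidin-1-yl group gives an at least 130-fold lower number from compound 1 to compound 4 (2.13 log units; beyond the scatter), a second saturated ring with a large step away from methyl, yet the same group still gives an 8.5-fold higher number from compound 2 to compound 4 (0.93 log units; beyond the scatter), so the distance from the 3-chlorophenyl group remains beyond the scatter. The value of compound 1 is a limit of the assay and not a number, so the step from it has only a bound: the limit of > 10000 nM in this assay, at which 1 of the 4 values shown sits.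

On these data alone, whether this ring carbon accepts groups other than fluoro remains open, for instance a hydroxyl, a methyl or an amine, since one substituent says little about the others. As far as these compounds go, it is also open whether a morpholine ring on the carbonyl carbon would stay with compound 3 and compound 4 or come closer to compound 2 in this assay.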